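Alkyl in place of acyl on the ring nitrogen

The compounds below may be only part of what the source reports. "The series", "measured", "known", "first", "only" and "open" are said of these compounds alone.

For the measured compounds named here, compound 3 `COc1ncc(-c2ccc3ncc(NC(C)=O)c(OC)c3c2)cc1NS(=O)(=O)c1ccc(F)cc1F` carries an acetyl on a nitrogen on an aromatic ring and, in a functional assay on HCT-116 cells (Homo sapiens) for antiproliferative activity, read by sulforhodamine B assay, with a stated time of 72 h (a lower number here means a stronger inhibitor, a higher number a weaker inhibitor), compound 3 gives 550 nM, the lowest of the three numbers measured so far, with both of its steps to the other compounds beyond the scatter. Compound 2 `CCNc1cnc2ccc(-c3cnc(OC)c(NS(=O)(=O)c4ccc(F)cc4F)c3)cc2c1OC`, with ethyl in that position, gives 1850 nM; the step of a 3.4-fold lower number from compound 2 to compound 3 (0.53 log units; beyond the scatter) is modest. Compound 1 `COc1ncc(-c2ccc3ncc(NC(=O)C4CCCCC4)c(OC)c3c2)cc1NS(=O)(=O)c1ccc(F)cc1F`, with cyclohexylcarbonyl, gives 4610 nM; the step of an 8.4-fold lower number from compound 1 to compound 3 (0.92 log units; beyond the scatter) is the largest in the set, and a 2.5-fold lower number from compound 1 to compound 2 (0.40 log units; beyond the scatter) shows the acyl-to-alkyl exchange on its own. Compound 4 `COc1ncc(-c2ccc3ncc(NCC4CCCCC4)c(OC)c3c2)cc1NS(=O)(=O)c1ccc(F)cc1F` is not yet measured. Its difference from compound 3 is cyclohexylmethyl in place of acetyl on a nitrogen on an aromatic ring. Going by the values given here, two measured steps bear on this change: a 3.4-fold lower number from compound 2 to compound 3 (0.53 log units; beyond the scatter), taken in reverse, is the closest model for exchanging acetyl for a plain alkyl, and an 8.4-fold lower number from compound 1 to compound 3 (0.92 log units; beyond the scatter) for enlarging methyl to cyclohexyl. Both point toward a higher number, and compound 4 combines the two changes. The expected step is a 15-fold higher number from compound 3 to compound 4 (1.16 log units; beyond the scatter), beyond the scatter. For compound 4 the estimate is 8000 nM, with a range from 2500 nM to 25000 nM.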

Compound 4, half-maximal inhibitory concentration: 13600 nM
For compound 4 the middle estimate is 1.7-fold (0.23 log units) below the measured one; the range from low to high includes it.
By their numbers in this assay, from the lowest: compound 3; then compound 2; then compound 1; then compound 4.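

In this assay, a 25-fold higher number from compound 3 to compound 4 (1.39 log units; beyond the scatter) is the largest step in the series, and compound 4 ends as the weakest of the four, with all of its steps beyond the scatter. Enlarging the group no longer depends on the carbonyl: a 7.4-fold higher number from compound 2 to compound 4 (0.87 log units; beyond the scatter) shows cyclohexyl in place of methyl raising the number on the alkyl form, in the same direction as an 8.4-fold lower number from compound 1 to compound 3 (0.92 log units; beyond the scatter) on the acyl form, read in reverse. With the cyclohexyl kept, a 3.0-fold higher number from compound 1 to compound 4 (0.47 log units; beyond the scatter) shows cyclohexylmethyl giving a higher number than cyclohexylcarbonyl, so the acyl form has the lower number in both matched pairs, compound 1 against compound 4 and compound 3 against compound 2, with neither pair going against this.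

No measurement shown here explains these steps. Open, going by these compounds, is whether a hydroxyl or a tertiary amine at the end of a short chain on this nitrogen, or a urea or a methanesulfonamide in place of the acetamido group, would hold or lower the number set by compound 3.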